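From 2-chloroethoxy to 4-chlorobutoxy on the shared core

A few compounds are considered here, and "the series" means these few. Any claim that something is new, unique, unknown or untested is made for them only; others in the source may bear on it.

Compound 1 `COc1ccc(Cc2coc3cc(O)cc(O)c3c2=O)cc1`: > 100000 nM, a limit of the assay.
Compound 2 `COc1ccc(Cc2coc3cc(OCCCl)cc(O)c3c2=O)cc1`: > 100000 nM, a limit of the assay.

In a functional assay on H9c2 cells (Mus musculus) for cytotoxicity against H9c2 (Rattus norvegicus), read by MTT assay, with a stated time of 24 h (on this read-out lower numbers stand for an effect already at smaller amounts and higher numbers for an effect only at larger amounts of compound), compound 1 gives > 100000 nM, which is a limit of the assay rather than a number. In this assay compound 2 likewise gives > 100000 nM, again a limit. Compound 2 therefore stands at the limit of > 100000 nM in this assay, at which 2 of the 2 values shown sit. Among the compounds with values here, the only measured step, a step that the two limits leave unreadable from compound 1 to compound 2, has no readable size, since both of its ends are limits. Compound 3 `COc1ccc(Cc2coc3cc(OCCCCCl)cc(O)c3c2=O)cc1` differs from compound 2 by 2-chloroethyl in place of chloro on a saturated chain carbon, two bonds along the chain from an oxygen on an aromatic ring, so the 2-chloroethoxy group of compound 2 becomes a 4-chlorobutoxy group. Within the data shown here, no measured step gives readable guidance on this change, so no step beyond the scatter is expected. The estimated step that the limit leaves unreadable from compound 2 to compound 3 is accordingly small. Compound 3 is expected to give about 150000 nM in this assay, within 60000 nM to 400000 nM, and most likely to be reported again only as a limit.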

Compound 3, half-maximal effective concentration: > 100000 nM
Compound 3: only a limit was reported; the forecaster's own chance of this, stated with the estimate: 85%; the middle value is on the limit's open side.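

In this assay, compound 1, compound 2 and compound 3 all give only a limit and not a number, so none of the steps among them can be read: the limit of > 100000 nM in this assay, at which 3 of the 3 values shown sit.

The compounds shown leave open whether lengthening the chain from 2-chloroethoxy to 4-chlorobutoxy changes the effect at all, and by how much.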